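Compound 3 to compound 4: an expected clearance

The source may hold more compounds than are shown below. What is called first, only, known or untested is meant among the compounds shown, and "the series" means these compounds.

The compounds measured so far in an in vitro ADME assay on microsomes from liver (Mus musculus) for pharmacokinetics, read by LC-MS, with a stated time of 10 min, tested at 1 uM (a higher number here means faster removal of the compound, a lower number slower removal), are these:
compound 1 `Cc1ccc(NC(=O)[C@H]2CN(C)C[C@@H]2c2ccc(/C=C/C(=O)Nc3ccccc3N)cc2)cc1` gives 62 mL/min/kg
compound 2 `CC(C)c1ccc(NC(=O)[C@H]2CN(C)C[C@@H]2c2ccc(/C=C/C(=O)Nc3ccccc3N)cc2)cc1` gives 54 mL/min/kg
compound 3 `CN1C[C@H](C(=O)Nc2ccc(F)c(Br)c2)[C@@H](c2ccc(/C=C/C(=O)Nc3ccccc3N)cc2)C1` gives 43 mL/min/kg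

All three values lie within the scatter of one another, so compound 3 stands with the other two and not apart from them. Compound 4 `CN1C[C@H](C(=O)Nc2ccc(Cl)cc2F)[C@@H](c2ccc(/C=C/C(=O)Nc3ccccc3N)cc2)C1` has not yet been measured. The difference from compound 3 reads 4-chloro-2-fluorophenyl in place of 3-bromo-4-fluorophenyl on an amide-type nitrogen and sits on an amide-type nitrogen.

Two measured steps at that same place (a 1.4-fold lower number from compound 1 to compound 3 (0.16 log units; within the scatter) and a 1.3-fold lower number from compound 2 to compound 3 (0.10 log units; within the scatter)) stayed within the scatter. A third step (a 1.1-fold lower number from compound 1 to compound 2 (0.06 log units; within the scatter)) came with isopropyl in place of methyl on an aromatic carbon and also stayed within it. For the measured compounds named here, no measured compound carries 4-chloro-2-fluorophenyl, and the three values give no direction for this change.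

In this assay no step beyond the scatter is therefore expected. The estimated step (a 1.1-fold higher number from compound 3 to compound 4 (0.05 log units; within the scatter)) is expected to stay inside it. For compound 4 the estimated clearance is 48 mL/min/kg with an expected range from 28 mL/min/kg to 80 mL/min/kg across repeated measurements.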

Compound 4, clearance: 43 mL/min/kg
Beside the measured number, compound 4's estimate is 1.1-fold (0.05 log units) above it; the range from low to high includes it.
By their numbers in this assay, from the lowest: compounds 3, 4, 2 and 1 (each within the scatter of the next).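

In this assay, for the compounds shown here, the exchange of 3-bromo-4-fluorophenyl for 4-chloro-2-fluorophenyl on the amide-type nitrogen gave no change at the digits printed from compound 3 to compound 4 (within the scatter) and thus showed for the first time that two phenyl groups each carrying two halogens, with different halogens and a different arrangement, can stand at this place with the same printed clearance. The new group also gave a 1.3-fold lower number from compound 2 to compound 4 (0.10 log units; within the scatter) and a 1.4-fold lower number from compound 1 to compound 4 (0.16 log units; within the scatter) so that, as with the 3-bromo-4-fluorophenyl group, neither step from the alkyl-substituted phenyl groups leaves the scatter, and all four groups at this place now read alike within the usual spread of the measurement. Nothing available explains why these clearance values stay together.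

Going by these compounds, whether this place stays as undemanding with a group of another kind remains open, for example a phenyl carrying an amine or a carboxylic acid, or a longer alkyl chain in place of the phenyl. All four compounds also share the rest of the structure, so what a change elsewhere in the shared core would do to clearance in this assay is left open as well.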